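Changing a Small Selenium Group on Compound 2

The compounds below may be only part of what the source reports. "The series", "measured", "known", "first", "only" and "open" are said of these compounds alone.

Within the data shown here, in a functional assay on RKO cells (Homo sapiens) for inhibition, read by MTT assay, with a stated time of 48 h (on this read-out lower numbers stand for stronger inhibition and higher numbers for weaker inhibition), compound 2 `COc1ccc(N(C)c2nc(C)nc3ccccc23)cc1[Se]C` gives 11 nM, the lower of the two numbers measured so far. In the same this assay, compound 1 `COc1ccc(N(C)c2nc(C)nc3ccccc23)cc1C(=O)OCC[Se]C#N` gives 2390 nM.

The unmeasured compound 3 `COc1ccc(N(C)c2nc(C)nc3ccccc23)cc1C[Se]C#N` departs from compound 2 on an aromatic carbon, ortho to a methoxy group: a group of 4 heavy atoms (2 carbon, 1 nitrogen, 1 selenium; no ring) in place of a group of 2 heavy atoms (1 carbon, 1 selenium; no ring), on an aromatic carbon. Among the measured compounds shown here, only one measured step bears on this change, and it falls at the same aromatic carbon. It is a 220-fold lower number from compound 1 to compound 2 (2.34 log units; beyond the scatter), a large step beyond the scatter, in which a group of 2 heavy atoms takes the place of a group of 8 heavy atoms. Compound 3 carries a group of 4 heavy atoms, which lies between those two in size. A single step gives only a rough guide, but its direction suggests a move toward a higher number, though probably not the full distance to compound 1. The expected change is an 11-fold higher number from compound 2 to compound 3 (1.04 log units; beyond the scatter), a clear rise in this assay. The estimate for compound 3 is 120 nM, with an expected range from 15 nM to 900 nM.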

Compound 3, half-maximal inhibitory concentration: 316 nM
Compound 3: middle estimate off by 2.6-fold (0.42 log units), on the low side; low and high end bracket the measured number.
By their numbers in this assay, from the lowest: compound 2; then compound 3; then compound 1.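

The result shows that this aromatic carbon, ortho to a methoxy group, tolerates little growth in this series, as even the group of 4 heavy atoms brings a 29-fold higher number from compound 2 to compound 3 (1.46 log units; beyond the scatter) in this assay. The larger group of 8 heavy atoms adds a smaller further change, seen in reverse as a 7.6-fold lower number from compound 1 to compound 3 (0.88 log units; beyond the scatter), so more of the total distance between compound 2 and compound 1 is covered by the first enlargement than by the second, and across these three compounds, with none going against it, the number rises as the group grows. Nothing shown here accounts for these differences.

The three compounds do not separate the effect of group size from that of the nitrile, as compound 1 and compound 3 both carry it and compound 2 does not, and all three carry selenium in this group. Going by these compounds, how a methylthio group, or a longer alkyl chain on selenium with no nitrile, would read at this carbon remains open.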